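Swapping the aryl on the triazole for a dinitrophenyl

The compounds below may be only part of what the source reports. "The series", "measured", "known", "first", "only" and "open" are said of these compounds alone.

Of the compounds shown here, three built on one shared core have been tested in a functional assay on HepG2 cells (Homo sapiens) for antiproliferative activity, read by MTT assay, with a stated time of 48 h; on this read-out higher numbers stand for weaker inhibition and lower numbers for stronger inhibition. Compound 1 `N#CC1=C(N)Oc2c(N)cc3nc4ccccc4nc3c2C12C(=O)N(Cc1cnnn1-c1ccc(F)cc1)c1ccccc12` carries a 4-fluorophenyl group on an aromatic nitrogen. In this assay compound 1 reaches only a limit of the assay, > 50000 nM. Compound 2 `N#CC1=C(N)Oc2c(N)cc3nc4ccccc4nc3c2C12C(=O)N(Cc1cnnn1-c1cc(Cl)ccc1Cl)c1ccccc12` carries a 2,5-dichlorophenyl group in that position, and in this assay compound 2 gives 33100 nM. Compound 3 `Cc1ccc(-n2nncc2CN2C(=O)C3(C(C#N)=C(N)Oc4c(N)cc5nc6ccccc6nc5c43)c3ccccc32)cc1Cl` carries a 3-chloro-4-methylphenyl group. In this assay compound 3 again sits at a limit of the assay, > 50000 nM. Compound 3 therefore stands at the edge of what the assay can report, a position it shares with one other compound (the limit of > 50000 nM in this assay, at which 2 of the 3 values shown sit). The step of an at least 1.5-fold higher number from compound 2 to compound 3 (0.17 log units; that floor lies within the scatter) lies within the scatter, as does an at least 1.5-fold lower number from compound 1 to compound 2 (0.17 log units; that floor lies within the scatter), while the step that the two limits leave unreadable from compound 1 to compound 3 cannot be read, both of its ends being limits.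

Compound 4 `N#CC1=C(N)Oc2c(N)cc3nc4ccccc4nc3c2C12C(=O)N(Cc1cnnn1-c1ccc([N+](=O)[O-])cc1[N+](=O)[O-])c1ccccc12` makes the change (2,4-dinitrophenyl in place of 3-chloro-4-methylphenyl on an aromatic nitrogen). Going by the values given here, none of the measured steps moved beyond the scatter, so no step beyond the scatter is expected here either; the estimate for compound 4 is 50000 nM, between 25000 nM and 100000 nM, which amounts to an expected step of a number no higher from compound 3 to compound 4 (the limit leaves the size open).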

Compound 4, half-maximal inhibitory concentration: 18400 nM
Estimate against measurement, compound 4: 2.7-fold (0.43 log units) above; measured number outside the range, below it.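

In this assay, a change on this aromatic nitrogen now gives a step that is readable and beyond the scatter: an at least 2.7-fold lower number from compound 3 to compound 4 (0.43 log units; beyond the scatter) and also an at least 2.7-fold lower number from compound 1 to compound 4 (0.43 log units; beyond the scatter) after 2,4-dinitrophenyl enters. The group does not separate compound 4 from every earlier compound, since a 1.8-fold lower number from compound 2 to compound 4 (0.26 log units; within the scatter) leaves those two unranked, so the 2,5-dichlorophenyl and 2,4-dinitrophenyl groups cannot be put in order here. From the compounds shown here alone, the two larger steps are only floors, and their true size stays unknown, as both start from a compound at the limit: the limit of > 50000 nM in this assay, at which 2 of the 4 values shown sit.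

Going by these compounds, it remains open whether both nitro groups are needed, or whether a phenyl ring with a single nitro group would give a similar number. The compounds shown also say nothing about an aminophenyl or carboxyphenyl group in this position.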